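A few compounds are considered here, and "the series" means these few. Any claim that something is new, unique, unknown or untested is made for them only; others in the source may bear on it.

Measured compounds:
Compound 1 `O=C(CCCSc1nc(O)cc(CCc2ccccc2)n1)NO` gives 205 nM in an assay on isolated protein for inhibition of histone deacetylase HD2 (Zea mays); a lower number here means a stronger inhibitor, a higher number a weaker inhibitor.
Compound 2 `O=C(CCCCCCSc1nc(O)cc(CCc2ccccc2)n1)NO` gives 83 nM in this assay.

Within the data shown here, compound 2 holds the lowest of the two numbers in this assay; the only other compound, compound 1, sits higher, the step being a 2.5-fold lower number from compound 1 to compound 2 (0.39 log units; beyond the scatter). Compound 3 `O=C(CCCCCCCSc1nc(O)cc(CCc2ccccc2)n1)NO` has not yet been measured. It differs from compound 2 as follows: (hydroxycarbamoyl)methyl in place of hydroxycarbamoyl on a saturated chain carbon, six bonds along the chain from a sulfur. Among the measured compounds shown here, the one measured step that bears on this is the earlier lengthening of the same chain, a 2.5-fold lower number from compound 1 to compound 2 (0.39 log units; beyond the scatter), which lowered the number beyond the scatter. The same kind of change is at hand again, so a further lowering is expected, though a smaller one, as a single measured step cannot show whether the gain continues at the same rate. The expected step is a 1.4-fold lower number from compound 2 to compound 3 (0.14 log units; within the scatter). Compound 3 is therefore estimated at 60 nM, with a range from 25 nM to 150 nM.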

Compound 3, half-maximal inhibitory concentration: 90 nM
For compound 3 the middle estimate is 1.5-fold (0.18 log units) below the measured one; the range from low to high includes it.
By their numbers in this assay, from the lowest: compounds 2 and 3 (each within the scatter of the next); then compound 1.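

In this assay, the further lengthening does not clearly extend the earlier gain: the step is a 1.1-fold higher number from compound 2 to compound 3 (0.04 log units; within the scatter) and so cannot be told apart from no change, which means that (hydroxycarbamoyl)methyl in place of hydroxycarbamoyl at this position makes no measurable difference. The advantage over the chain of compound 1 remains, with a 2.3-fold lower number from compound 1 to compound 3 (0.36 log units; beyond the scatter) as the step, so compound 2 and compound 3 both stand apart from compound 1 but not from each other. Nothing at hand gives a reason for this result.

On these data alone, it remains open whether a longer chain than that of compound 3 would hold this level or lose it. The compounds shown also leave open how a carboxylic acid in place of the hydroxycarbamoyl end would read in this assay.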